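The source may hold more compounds than are shown below. What is called first, only, known or untested is meant among the compounds shown, and "the series" means these compounds.

Measured so far: compound 1 `O=C(Nc1cccc(-n2cc(-c3ccncc3)c(-c3ccc(Cl)c(O)c3)n2)c1)Nc1cccc(C(F)(F)F)c1` gives 1060 nM in a functional assay on OVCAR-3 cells (Homo sapiens) for inhibition, read by sulforhodamine B assay, with a stated time of 48 h; a lower number here means a stronger inhibitor, a higher number a weaker inhibitor; compound 2 `COc1cc(-c2nn(-c3cccc(NC(=O)Nc4cc(C(F)(F)F)cc(C(F)(F)F)c4)c3)cc2-c2ccncc2)ccc1Cl` gives 410 nM in this assay.

Compound 2 holds the lower of the two numbers; compound 1 sits above it, beyond the scatter, though the two differ in more than one place. Compound 3 `O=C(Nc1cccc(-n2cc(-c3ccncc3)c(-c3ccc(Cl)c(O)c3)n2)c1)Nc1cc(C(F)(F)F)cc(C(F)(F)F)c1` differs from compound 2 by hydrogen in place of methyl on an oxygen on an aromatic ring. Going by the values given here, no measured pair isolates this change, so the size of its step in this assay cannot be read from the data. A small loss, or no step beyond the scatter, is expected, since compound 1, which also carries the hydroxy, shows 1060 nM. Compound 3 is expected to give 600 nM, within 250 nM to 1500 nM. The implied step is expected to be a 1.5-fold higher number from compound 2 to compound 3 (0.17 log units; within the scatter).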

Compound 3, half-maximal inhibitory concentration: 400 nM
Compound 3: middle estimate off by 1.5-fold (0.18 log units), on the high side; low and high end bracket the measured number.
By their numbers in this assay, from the lowest: compounds 3 and 2 (each within the scatter of the next); then compound 1.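

In this assay, going from methoxy to hydroxy gives a 1.0-fold lower number from compound 2 to compound 3 (0.01 log units; within the scatter), so this position does not separate the two groups when the second trifluoromethyl is present. Going by these compounds alone, with the hydroxy held fixed, trifluoromethyl in place of hydrogen on an aromatic carbon gives a 2.7-fold lower number from compound 1 to compound 3 (0.42 log units; beyond the scatter), a modest step and the only single-place step so far beyond the scatter. No evidence available here bears on the reason for either step.

On these data alone, whether an ethoxy group or an amine in place of the hydroxy would keep this level remains open. Also open, as far as these compounds go, is whether the trifluoromethyl step would hold with methoxy on the oxygen.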